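The compounds below may be only part of what the source reports. "The series", "measured", "known", "first", "only" and "open" are said of these compounds alone.

In a functional assay on HepG2 cells (Homo sapiens) for cytotoxicity, read by MTT assay, with a stated time of 72 h (on this read-out higher numbers stand for weaker inhibition and lower numbers for stronger inhibition), compound 3 `COc1cc2ncnc(Nc3ccc(F)c(Cl)c3)c2cc1NC(=O)N/N=C/c1ccc([N+](=O)[O-])cc1` gives 34100 nM, level with compound 2 `COc1cc2ncnc(Nc3ccc(F)c(Cl)c3)c2cc1NC(=O)N/N=C/c1ccc(C#N)cc1` at 34100 nM and within the scatter of compound 1 `O=C(N/N=C/c1ccc([N+](=O)[O-])cc1)Nc1cc2c(Nc3ccc(F)c(Cl)c3)ncnc2cc1O[C@H]1CCOC1` at 35300 nM. Compound 4 `COc1cc2ncnc(Nc3ccc(F)c(Cl)c3)c2cc1NC(=O)N/N=C/c1cc(OC)c(OC)c(OC)c1` differs from compound 3 as follows: 3,4,5-trimethoxyphenyl in place of 4-nitrophenyl on a carbon with a double bond to nitrogen. Within the data shown here, two measured steps bear on this: no change at the digits printed from compound 2 to compound 3 (within the scatter), a nitro-for-cyano swap, and a 1.0-fold lower number from compound 1 to compound 3 (0.02 log units; within the scatter), a methyl-for-oxolan-3-yl swap. Both lie within the scatter, but neither replaces the whole 4-nitrophenyl, so the range stays wide. No step beyond the scatter is therefore expected in this assay, and any drift towards a lower number would be slight. The estimated change is a 1.1-fold lower number from compound 3 to compound 4 (0.06 log units; within the scatter). Compound 4 is expected at 30000 nM, within a range of 11000 nM to 70000 nM.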

Compound 4, half-maximal inhibitory concentration: 30100 nM
Compound 4: middle estimate off by 1.0-fold (0.00 log units), on the low side; measured number inside the range.
By their numbers in this assay, from the lowest: compounds 4, 2, 3 and 1 (each within the scatter of the next).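

In this assay, exchanging the whole aryl group on the carbon with a double bond to nitrogen stays within the scatter: 3,4,5-trimethoxyphenyl in place of 4-nitrophenyl gives a 1.1-fold lower number from compound 3 to compound 4 (0.05 log units; within the scatter), and in place of 4-cyanophenyl gives a 1.1-fold lower number from compound 2 to compound 4 (0.05 log units; within the scatter). Earlier steps at this position covered only a nitro-for-cyano swap, whereas these steps replace the aryl group with a larger one, of 12 heavy atoms rather than 9. Nothing measured accounts for this flat result. On these data alone, whether a phenyl ring carrying an amine or a carboxylic acid, or a longer alkyl chain in place of the ring, would give a step beyond the scatter remains open.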